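From dimethylamino to methoxy at one aromatic carbon

The source may hold more compounds than are shown below. What is called first, only, known or untested is meant among the compounds shown, and "the series" means these compounds.

In an ADME assay on HPC cells (Homo sapiens) for cytotoxicity, with a stated time of 24 h (a higher number here means that more compound is tolerated, a lower number that less compound is tolerated), compound 2 `CN(C)c1ccc(/C=C2\CCC/C(=C\c3cccc([N+](=O)[O-])c3)C2=O)cc1` gives > 400000 nM as its reading, and that is a limit of the assay, not a number. Compound 1 `O=C1/C(=C/c2ccccc2)CCC/C1=C\c1cccc([N+](=O)[O-])c1` has hydrogen where compound 2 carries dimethylamino, and compound 1 gives 14000 nM as a measured number. Among the measured compounds shown here, the one measured step is an at least 28-fold higher number from compound 1 to compound 2 (1.45 log units; beyond the scatter) and it is large, with its true size open on one side. Compound 3 `COc1ccc(/C=C2\CCC/C(=C\c3cccc([N+](=O)[O-])c3)C2=O)cc1` keeps the shared core and has methoxy in place of dimethylamino on an aromatic carbon, para to a large group, the change being methoxy in place of dimethylamino on an aromatic carbon in full. For the measured compounds named here, only that one step bears on this change, and it compares dimethylamino with hydrogen, not with methoxy. Some of the rise may survive in compound 3, but a large step down is expected, towards compound 1 at 14000 nM without reaching it. The estimated change is an at least 5.7-fold lower number from compound 2 to compound 3 (0.75 log units; beyond the scatter) and it remains uncertain, since compound 2 has no exact number. Compound 3 is estimated at 70000 nM in this assay with 20000 nM to 300000 nM as its expected range.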

Compound 3, half-maximal cytotoxic concentration: 33000 nM
Estimate against measurement, compound 3: 2.1-fold (0.33 log units) above; the range from low to high includes it.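

In this assay, the new group at this aromatic carbon gives an at least 12-fold lower number from compound 2 to compound 3 (1.08 log units; beyond the scatter), so the high reading of compound 2 does not carry over to a second group of similar size at the same place. Methoxy in place of hydrogen gives only a 2.4-fold higher number from compound 1 to compound 3 (0.37 log units; beyond the scatter), a modest step that is still beyond the scatter, so the three compounds fall in the order hydrogen, methoxy, dimethylamino, and most of the rise belongs to dimethylamino alone. The full size of the step from methoxy to dimethylamino stays unknown, since compound 2 has no exact number and is held only by a limit of the assay: the limit of > 400000 nM in this assay, at which 1 of the 3 values shown sits.

Three compounds at one position cannot tell what sets this order, and nothing measured here gives a property of either group that would explain it. Going by these compounds, how a primary amine, a hydroxyl or a longer ether such as ethoxy would read at this place remains open, as does whether dimethylamino would raise the number in the same way at another carbon of the ring.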